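The source may hold more compounds than are shown below. What is called first, only, known or untested is meant among the compounds shown, and "the series" means these compounds.

Two compounds of the series have numbers in an assay on isolated protein for inhibition of DNA topoisomerase 1 (Homo sapiens), with a stated time of 30 min, tested at 100 uM; a higher number here means a stronger effect of the compound at the concentration tested, a lower number a weaker effect. Compound 1 `Oc1ccc(-c2cc(-c3cccnc3)nc(-c3cccc(Cl)c3)c2)cc1` gives 55.2%. Compound 2 `Oc1ccc(-c2cc(-c3ccsc3)nc(-c3cccc(Cl)c3)c2)cc1` gives 26%, the lower of the two numbers and the nearest neighbour of compound 1, the gap being beyond the scatter. For the measured compounds named here, the only step measured so far is a number 29.2 percentage points lower from compound 1 to compound 2 (beyond the scatter). Compound 3 `Oc1ccc(-c2cc(-c3cccc(Cl)c3)nc(-c3ccco3)c2)cc1` has not yet been measured.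

furan-2-yl in place of thiophen-3-yl on an aromatic carbon

Going by the values given here, no measured step exchanges thiophen-3-yl for furan-2-yl, and the step from compound 1 to compound 2, which put thiophen-3-yl in place of pyridin-3-yl, does not bear directly on this change. Both groups carry the same counts of heavy atoms and of acceptors, so the expected step is a number 2 percentage points higher from compound 2 to compound 3 (within the scatter), that is none beyond the scatter, with a wide range to cover the lack of a bearing step. Compound 3 is expected to give 28%, between 8% and 50%.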

Compound 3, a percentage reported as inhibition, at one concentration (the size of the read-out at that concentration, not a potency): 25.5%
The estimate for compound 3 lay 2.5 percentage points above the measured number; low and high end bracket the measured number.
By their numbers in this assay, from the lowest: compounds 3 and 2 (each within the scatter of the next); then compound 1.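

At this place, next to the ring nitrogen, in this assay, the exchange of thiophen-3-yl for furan-2-yl gives a number 0.5 percentage points lower from compound 2 to compound 3 (within the scatter), so swapping sulfur for oxygen, together with the different point of attachment, separates nothing here. The drop seen earlier with thiophen-3-yl is therefore not peculiar to that group: furan-2-yl in place of pyridin-3-yl gives a number 29.7 percentage points lower from compound 1 to compound 3 (beyond the scatter), and in this set both five-membered rings stand apart from the pyridin-3-yl of compound 1. No measurement available here offers an explanation for this pattern.

These compounds leave open whether the higher number of compound 1 goes with the ring nitrogen or with the six-membered ring itself. A plain phenyl or a pyridin-4-yl at this place would separate those two readings, and an amine on the pyridin-3-yl ring would show whether the number can rise further.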